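The source may report more compounds than this note shows. Statements on the series, on what has been measured and on what is new or still open speak of the compounds shown alone.

Compound 2 `c1ccc(-c2nccs2)c(OCC2=NCCN2)c1` gives 102% in a functional assay with Alpha-1A adrenergic receptor (Homo sapiens) as the target, read by calcium flux (on this read-out lower numbers stand for smaller maximal responses and higher numbers for larger maximal responses), and stands level, within the scatter, with compound 1 `c1ccc(-c2ccoc2)c(OCC2=NCCN2)c1`, which gives 104%; the step of a number 2 percentage points lower from compound 1 to compound 2 (within the scatter) is within the scatter. Compound 3 `Cc1cnsc1-c1ccccc1OCC1=NCCN1` differs from compound 2 by 4-methyl-1,2-thiazol-5-yl in place of 1,3-thiazol-2-yl on an aromatic carbon. Among the compounds with values here, the only measured step, a number 2 percentage points lower from compound 1 to compound 2 (within the scatter), likewise exchanged one five-membered aromatic ring with 2 hetero atoms for another and left the maximal response unchanged. For compound 3 a step of a number 2 percentage points lower from compound 2 to compound 3 (within the scatter) is expected, none beyond the scatter. Compound 3 is thus estimated to give 100%, between 88% and 112%.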

Compound 3, largest response reached (reported as maximum), in percent of the reference or control that the assay uses: 104%
Compound 3: the middle estimate sits 4 percentage points below what was measured; the range from low to high includes it.
By their numbers in this assay, from the lowest: compounds 2, 1 and 3 (each within the scatter of the next).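

With 4-methyl-1,2-thiazol-5-yl on this aromatic carbon, the exchange for 1,3-thiazol-2-yl gave a number 2 percentage points higher from compound 2 to compound 3 (within the scatter), and the exchange for furan-3-yl gave no change at the digits printed from compound 1 to compound 3 (within the scatter). The maximal response at this position therefore stayed level with a larger group that carries a methyl on its ring, not only with the unsubstituted five-membered aromatic rings. No measurement offered here accounts for this result. The compounds shown leave open whether the maximal response stays level with an amine or a carboxylic acid on this aromatic carbon in place of the five-membered aromatic ring.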